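The source may report more compounds than this note shows. Statements on the series, on what has been measured and on what is new or still open speak of the compounds shown alone.

Compound 1 `O=C1/C(=N\NC(=S)Nc2ccc(Cl)cc2)c2cc(Cl)ccc2N1Cc1ccc(Cl)cc1` gives 124000 nM in a functional assay on L1210 cells (Mus musculus), with a stated time of 48 h (on this read-out higher numbers stand for weaker inhibition and lower numbers for stronger inhibition), and compound 2 `O=C1/C(=N\NC(=S)Nc2ccc(Cl)cc2)c2cc(Cl)ccc2N1Cc1ccc(F)cc1` gives 103000 nM; a 1.2-fold lower number from compound 1 to compound 2 (0.08 log units; within the scatter), so the two values stand together. Compound 3 `O=C1/C(=N\NC(=S)Nc2ccc(Cl)cc2)c2cc(Br)ccc2N1Cc1ccc(Cl)cc1` differs from compound 1 by bromo in place of chloro on an aromatic carbon. Among the measured compounds shown here, the only measured step, a swap of one halogen for another elsewhere on the shared core, stayed within the scatter, and no measured step touches the place altered here. A change of no more than the scatter is therefore expected, no change at the digits printed from compound 1 to compound 3 (within the scatter). Compound 3 is estimated at 124000 nM, with a range from 60000 nM to 250000 nM.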

Compound 3, half-maximal inhibitory concentration: >= 500000 nM
Compound 3 ended at the assay's limit (the forecaster's own chance of this, stated with the estimate: 10%); middle value at least 4.0-fold (0.60 log units) away from the limit.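

At this position on the shared core, bromo in place of chloro gives an at least 4.0-fold higher number from compound 1 to compound 3 (0.60 log units; beyond the scatter), so inhibition is weaker and this place responds to a swap of one halogen for another, unlike the swap elsewhere, which gave a 1.2-fold lower number from compound 1 to compound 2 (0.08 log units; within the scatter). For compound 3, the reading of >= 500000 nM is a limit of the assay and not a number. The full size of the step therefore stays unfixed: the limit of >= 500000 nM in this assay, at which 1 of the 3 values shown sits.

The compounds shown carry only chloro and bromo at this position. Going by these compounds, how a methoxy group or an amine there would read in this assay stays open.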